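Pyridin-2-yl for phenyl on the tetrazole ketone

The compounds below may be only part of what the source reports. "The series", "measured", "known", "first", "only" and "open" are said of these compounds alone.

Measured compounds:
compound 1, `CCCCCCCCc1ccc(OCC(=O)Cn2nnc(-c3ccccc3)n2)cc1`, 24 nM
compound 2, `CCCCCCCCc1ccc(OCC(=O)Cn2nnnc2-c2ccccc2)cc1`, 71 nM

Both compounds were tested in an assay on microsomes from brain for inhibition of Fatty-acid amide hydrolase 1 (Rattus norvegicus), read by fluorescence and HPLC, with a stated time of 60 min; a higher number here means a weaker inhibitor, a lower number a stronger inhibitor. Compound 1 gives 24 nM, and compound 2 gives 71 nM. Of the two numbers, compound 2 has the higher one; compound 1 is its nearest neighbour, with a lower number, and that gap lies beyond the scatter of repeated measurements. Among the measured compounds shown here, the two compounds differ in where the phenyl ring sits on the shared core, and no single-point step between them is recorded.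

Compound 3, `CCCCCCCCc1ccc(OCC(=O)Cn2nnnc2-c2ccccn2)cc1`, has not yet been measured in this assay. It differs from compound 2 in one place: pyridin-2-yl in place of phenyl on an aromatic carbon. For the measured compounds named here, no measured pair shows the effect of this change, so its size cannot be read from the data at hand. The author expects a modest shift towards a lower number, and estimates the step of a 1.8-fold lower number from compound 2 to compound 3 (0.25 log units; within the scatter), with a step of no more than the scatter also possible. For compound 3 the estimated value in this assay is 40 nM, within a range of 12 nM to 150 nM.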

Compound 3, half-maximal inhibitory concentration: 880 nM
Beside the measured number, compound 3's estimate is 22-fold (1.34 log units) below it, outside the stated range (above it).
By their numbers in this assay, from the lowest: compound 1; then compound 2; then compound 3.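

In this assay, putting pyridin-2-yl in place of phenyl gives a 12-fold higher number from compound 2 to compound 3 (1.09 log units; beyond the scatter) and so a much weaker inhibitor, which shows that this aromatic carbon of the five-membered aromatic ring with 4 nitrogen does not tolerate every six-membered aromatic ring equally. The two groups have the same count of heavy atoms, and the change is one ring carbon for one ring nitrogen, with one hydrogen-bond acceptor entering, so an exchange this small in its counts is enough to produce a large step here. (Nothing measured here accounts for the size of this step).

The compounds shown leave open whether the weaker inhibition belongs to any ring nitrogen or to pyridin-2-yl in particular, a question that pyridin-3-yl or pyridin-4-yl at the same place would address. They also leave open whether pyridin-2-yl in place of phenyl on the core of compound 1 would give a step of similar size, or whether this large step is confined to the core of compound 2.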